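This account rests on a few compounds, and the source may have more. Where it says the series, first, only, none or still open, it means among the compounds named here.

Working notes on the series. The measured compounds share one core and differ only at the group on an amide-type nitrogen. In a functional assay (Pituitary gland cell) with Rattus norvegicus as the target (a higher number here means that more compound is needed for the effect, a lower number that less compound is needed), compound 1 `CC(C)(N)C(=O)N[C@@H]1CCc2ccccc2N(Cc2ccc(-c3ccccc3CNC(N)=O)cc2)C1=O` gives 21 nM. In this assay compound 2 `CCNC(=O)NCc1ccccc1-c1ccc(CN2C(=O)[C@H](NC(=O)C(C)(C)N)CCc3ccccc32)cc1` gives 6 nM. In this assay compound 3 `CC(C)NC(=O)NCc1ccccc1-c1ccc(CN2C(=O)[C@H](NC(=O)C(C)(C)N)CCc3ccccc32)cc1` gives 270 nM, the highest number of the three: a 13-fold higher number from compound 1 to compound 3 (1.11 log units; beyond the scatter), and a 45-fold higher number from compound 2 to compound 3 (1.65 log units; beyond the scatter). The opposite direction appears in a 3.5-fold lower number from compound 1 to compound 2 (0.54 log units; beyond the scatter).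

Compound 4 `CN(C)C(=O)NCc1ccccc1-c1ccc(CN2C(=O)[C@H](NC(=O)C(C)(C)N)CCc3ccccc32)cc1` is not yet measured. Its change from compound 3 is dimethylamino in place of isopropylamino on a carbonyl carbon. Among the measured compounds shown here, no measured step matches this change directly. The step that bears on it most is a 45-fold higher number from compound 2 to compound 3 (1.65 log units; beyond the scatter), a large rise in the number on adding a methyl at the substituent; the present change removes carbon from that substituent again but also removes the hydrogen-bond donor counted for isopropylamino, and nothing measured shows what that donor contributes. The second relevant step, a 13-fold higher number from compound 1 to compound 3 (1.11 log units; beyond the scatter), likewise penalised isopropyl. Compound 4 is therefore expected to fall somewhat below compound 3, an estimated step of a 1.8-fold lower number from compound 3 to compound 4 (0.26 log units; within the scatter), with wide uncertainty. In this assay compound 4 is expected at 150 nM, within a range from 30 nM to 800 nM.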

Compound 4, concentration for half-maximal effect: 60 nM
The estimate for compound 4 lay 2.5-fold (0.40 log units) above the measured number; the range from low to high includes it.
By their numbers in this assay, from the lowest: compound 2; then compound 1; then compound 4; then compound 3.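

In this assay dimethylamino in place of isopropylamino on a carbonyl carbon gives a 4.5-fold lower number from compound 3 to compound 4 (0.65 log units; beyond the scatter) and so recovers part of the rise seen with isopropylamino, even though dimethylamino has no hydrogen-bond donor counted. The recovery is incomplete, with a 10-fold higher number from compound 2 to compound 4 (1.00 log units; beyond the scatter) for dimethylamino in place of ethylamino and a 2.9-fold higher number from compound 1 to compound 4 (0.46 log units; beyond the scatter) for dimethylamino in place of amino, which places compound 4 between compound 1 and compound 3 in the order of numbers. Across these four compounds the number at this position does not simply rise with added carbon, as compound 2 has the lowest number and goes against such a trend, and nothing available accounts for these differences.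

The compounds shown leave open what the donor on this nitrogen contributes on its own, as isopropylamino and dimethylamino also differ in their carbon groups. Methylamino and a longer chain such as n-propylamino on the same carbonyl carbon would show whether the high number of compound 3 goes with the isopropyl group in particular or with the size of the chain more generally.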